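Pentyl chain in place of the isopentyloxy group

The compounds below may be only part of what the source reports. "The series", "measured", "known", "first", "only" and "open" are said of these compounds alone.

Among the compounds with values here, compound 2 `CC(C)CCOc1cc(C(C)(C)C)ccc1CNC(=O)C(C)c1ccc(NS(C)(=O)=O)c(F)c1` gives the lowest of the two numbers so far, 0.6 nM in an assay on cells for antagonist activity at transient receptor potential cation channel subfamily V member 1 (Homo sapiens), read by FLIPR and calcium flux, with a stated time of 6 min; a higher number here means a weaker inhibitor, a lower number a stronger inhibitor; the nearest, compound 1 `CCCOc1cc(C(C)(C)C)ccc1CNC(=O)C(C)c1ccc(NS(C)(=O)=O)c(F)c1`, gives 4.4 nM, and a 7.3-fold lower number from compound 1 to compound 2 (0.87 log units; beyond the scatter). Compound 3 `CCCCCc1cc(C(C)(C)C)ccc1CNC(=O)C(C)c1ccc(NS(C)(=O)=O)c(F)c1` carries pentyl in place of isopentyloxy on an aromatic carbon, the place being ortho to a large group and meta to the tert-butyl group. Within the data shown here, the one step known, from compound 1 to compound 2, changed only the chain, not the linking oxygen, so it bears on this change only loosely. A small loss is expected, a 2.5-fold higher number from compound 2 to compound 3 (0.40 log units; beyond the scatter), and compound 3 is estimated at 1.5 nM in this assay, within 0.4 nM to 6 nM.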

Compound 3, inhibition constant: 2.8 nM
The estimate for compound 3 lay 1.9-fold (0.27 log units) below the measured number; the measured number falls inside the stated range.
By their numbers in this assay, from the lowest: compound 2; then compounds 3 and 1 (each within the scatter of the next).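

In this assay, pentyl in place of isopentyloxy gives a 4.7-fold higher number from compound 2 to compound 3 (0.67 log units; beyond the scatter) and so shows that this aromatic carbon does not tolerate every chain equally, even though the swap removes only the linking oxygen and the branch. Pentyl in place of propoxy gives a 1.6-fold lower number from compound 1 to compound 3 (0.20 log units; within the scatter) and thus shows that a chain without the oxygen can match compound 1. No evidence is at hand to explain either step. Whether the oxygen or the branch matters more stays open, since neither pentyloxy nor isopentyl appears among these compounds. From the compounds shown here alone, how a chain ending in an amine would behave here is also open.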